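Alkoxy chain variation on the shared core

A few compounds are considered here, and "the series" means these few. Any claim that something is new, unique, unknown or untested is made for them only; others in the source may bear on it.

Compound 2 `CCOC(=O)Nc1ccc([Se]C#N)cc1` in a functional assay on MCF7 cells (Homo sapiens) for cytotoxicity, read by MTT assay, with a stated time of 72 h (a lower number here means a stronger inhibitor of growth, a higher number a weaker inhibitor of growth), gives 8900 nM, the highest of the two numbers recorded so far; its nearest neighbour is compound 1 `N#C[Se]c1ccc(NC(=O)OCc2ccccc2)cc1`, which in this assay gives 8700 nM. Among the measured compounds shown here, the one measured step at this position, a 1.0-fold higher number from compound 1 to compound 2 (0.01 log units; within the scatter), shows that exchanging the group on the saturated chain carbon bound to an oxygen next to a carbonyl group left the read-out unchanged. Compound 3 `CC(C)COC(=O)Nc1ccc([Se]C#N)cc1` carries the difference isopropyl in place of methyl on a saturated chain carbon bound to an oxygen next to a carbonyl group relative to compound 2, so that ethoxy becomes isobutoxy. For the measured compounds named here, since the only comparable step, a 1.0-fold higher number from compound 1 to compound 2 (0.01 log units; within the scatter), stayed within the scatter, no shift beyond the scatter is expected in this assay for this change either. Compound 3 is therefore expected to give about 9000 nM in this assay, with a range from 4500 nM to 18000 nM. The step of a 1.0-fold higher number from compound 2 to compound 3 (0.00 log units; within the scatter) is accordingly expected to be essentially flat.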

Compound 3, concentration for 50% growth inhibition in the MCF7 assay: 18100 nM
Beside the measured number, compound 3's estimate is 2.0-fold (0.30 log units) below it, and the stated range ends below it.
By their numbers in the MCF7 assay, from the lowest: compounds 1 and 2 (each within the scatter of the next); then compound 3.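

In the MCF7 assay this position does respond to the group it carries, since ethoxy to isobutoxy gives a 2.0-fold higher number from compound 2 to compound 3 (0.31 log units; beyond the scatter) and the change of phenyl to isopropyl on the same carbon gives a 2.1-fold higher number from compound 1 to compound 3 (0.32 log units; beyond the scatter) as a second modest step. Methyl and phenyl read alike here, whereas isopropyl goes with weaker growth inhibition than either, so the flat first step does not hold for every group at this position. In a physicochemical assay, with a stated time of 180 min, tested at 0.5 mg/mL (on this read-out higher numbers stand for more inhibition at the one concentration tested (going by the name of the read-out) and lower numbers for less inhibition), compound 2 gives 37% and compound 3 gives 27.1% and this difference, a number 9.9 percentage points lower from compound 2 to compound 3 (within the scatter) as printed, separates neither compound from the other.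

Nothing available accounts for the shift in growth inhibition. Still open, as far as these compounds go, is whether a longer straight chain or a terminal amine on this carbon would follow isopropyl or stay level with methyl and phenyl.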